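The source may report more compounds than this note shows. Statements on the series, on what has been measured and on what is new or still open speak of the compounds shown alone.

Measured in a functional assay on MCF7 cells (Homo sapiens) for antiproliferative activity, read by CCK-8 assay, with a stated time of 24 h; a lower number here means a stronger inhibitor, a higher number a weaker inhibitor:
Compound 1 `C/C(=N\NC(=O)Nc1nc2ccc(CN(C)C)cc2s1)c1ccccn1`: > 40000 nM
Compound 2 `C/C(=N\NC(=O)Nc1nc2ccc(CN(C)C)cc2s1)c1cnccn1`: > 40000 nM
Compound 3 `CCN(CC)Cc1ccc2nc(NC(=O)N/N=C/c3ccccn3)sc2c1`: > 40000 nM

None of these readings is a number, and together they amount to the limit of > 40000 nM in this assay, at which 3 of the 3 values shown sit. Compound 2 gives > 40000 nM, which is a limit of the assay, so it cannot be ranked against the other two.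

Compound 4 `C/C(=N\NC(=O)Nc1nc2ccc(CN3CCC(C)CC3)cc2s1)c1cnccn1` differs from compound 2 in one place: 4-methylpiperidin-1-yl in place of dimethylamino on a saturated chain carbon bound to an aromatic carbon. In words, 4-methylpiperidin-1-yl stands in place of dimethylamino on a saturated chain carbon bound to an aromatic carbon.

For the measured compounds named here, the one measured step, a step that the two limits leave unreadable from compound 1 to compound 2, lies at another place in the structure and gives no size to carry over. Going by the values given here, no measured step covers this exchange. Since compound 2 reads > 40000 nM, again a limit, no step beyond the scatter is expected in this assay, and no direction can be favoured. The expected result is a number no higher from compound 2 to compound 4 (the limit leaves the size open). For compound 4 the estimate is 40000 nM, with an expected range of 12000 nM to 60000 nM.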

Compound 4, half-maximal inhibitory concentration: 11800 nM
Estimate against measurement, compound 4: 3.4-fold (0.53 log units) above; measured number outside the range, below it.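

In this assay, compound 4 is the only one of the compounds shown that gives a number rather than a limit. For the compounds shown here, putting 4-methylpiperidin-1-yl in place of dimethylamino on the saturated chain carbon bound to an aromatic carbon gives an at least 3.3-fold lower number from compound 2 to compound 4 (0.53 log units; beyond the scatter), so this position can move the read-out, which the earlier compounds could not show, as the one earlier step cannot be read. The size of this step remains a lower bound because compound 2 stands at a limit: the limit of > 40000 nM in this assay, at which 3 of the 4 values shown sit.

The compounds shown leave open whether the ring or its methyl carries the step, which piperidin-1-yl without the methyl, morpholin-4-yl or piperazin-1-yl in the same place would help to separate. They also leave open whether the same exchange would lower the number with the pyridin-2-yl group of compound 1.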